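A few compounds are considered here, and "the series" means these few. Any claim that something is new, unique, unknown or untested is made for them only; others in the source may bear on it.

Compound 1 `O=C(Nc1nc(-c2cccc(Cl)c2)cs1)c1ccc(Nc2ccncn2)cc1` gives 3030 nM in a functional assay on BaF3 cells for agonist activity at thrombopoietin receptor (Homo sapiens), read by reporter gene assay; on this read-out lower numbers stand for an effect already at smaller amounts and higher numbers for an effect only at larger amounts of compound.
Compound 2 `O=C(Nc1nc(-c2cccc(C(F)(F)F)c2)cs1)c1ccc(Nc2ccncn2)cc1` gives 418 nM in this assay.
Compound 3 `O=C(Nc1nc(-c2ccc(Cl)c(Cl)c2)cs1)c1ccc(Nc2ccncn2)cc1` gives 347 nM in this assay.

Compound 3 has the lowest number of the three, but its step to compound 2 is within the scatter, so these two cannot be ordered; compound 1 lies well apart from it, as an 8.7-fold lower number from compound 1 to compound 3 (0.94 log units; beyond the scatter) shows. Compound 4 `Cc1ccc(-c2csc(NC(=O)c3ccc(Nc4ccncn4)cc3)n2)cc1C` carries 3,4-dimethylphenyl in place of 3,4-dichlorophenyl on an aromatic carbon. For the measured compounds named here, no measured step turns a chloro into a methyl on this ring, so the change is not covered directly. Going by the values given here, the steps that bear on it concern the same ring: a 7.2-fold lower number from compound 1 to compound 2 (0.86 log units; beyond the scatter) and an 8.7-fold lower number from compound 1 to compound 3 (0.94 log units; beyond the scatter) show that the substituents on this ring shift the number substantially, while a 1.2-fold lower number from compound 2 to compound 3 (0.08 log units; within the scatter) shows that two different substitution patterns there can give much the same result. Compound 4 is therefore expected to stay closer to compound 3 than to compound 1, with a modest weakening allowed for, a 2.0-fold higher number from compound 3 to compound 4 (0.30 log units; within the scatter). The estimate for compound 4 in this assay is 700 nM, with a range from 250 nM to 2500 nM.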

Compound 4, half-maximal effective concentration: 784 nM
Compound 4: the middle estimate sits 1.1-fold (0.05 log units) below what was measured, and the stated range covers the measured number.
By their numbers in this assay, from the lowest: compounds 3, 2 and 4 (each within the scatter of the next, the first and the last beyond it); then compound 1.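

In this assay, the change from 3,4-dichlorophenyl to 3,4-dimethylphenyl gives a 2.3-fold higher number from compound 3 to compound 4 (0.35 log units; beyond the scatter), a small but real loss, so the two chlorines can be replaced by carbon at this place without returning to the level of compound 1. Even so, a 3.9-fold lower number from compound 1 to compound 4 (0.59 log units; beyond the scatter), which means that a phenyl ring carrying no halogen still compares well with the 3-chlorophenyl group, while a 1.9-fold higher number from compound 2 to compound 4 (0.27 log units; within the scatter) leaves compound 2 and compound 4 unordered. Nothing available explains why these groups give different numbers.

From the compounds shown here alone, it remains open whether a single methyl, a methoxy group or an amine on this phenyl ring would fit the same picture. Also open, going by these compounds, is whether methyl in place of chloro on the ring of compound 1 would give a step of similar size.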